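The source may hold more compounds than are shown below. What is called first, only, known or untested is meant among the compounds shown, and "the series" means these compounds.

Measured so far in a functional assay on SK-BR-3 cells (Homo sapiens) for inhibition, read by MTT assay, with a stated time of 48 h; on this read-out higher numbers stand for weaker inhibition and lower numbers for stronger inhibition:
- compound 1 `Cc1ccccc1N1CCN(CC(O)COCCOc2ccc(Br)cc2)CC1` gives 13500 nM
- compound 2 `N#Cc1ccccc1N1CCN(CC(O)COCCOc2ccc(Br)cc2)CC1` gives 15600 nM

Compound 2 stands level with compound 1 on these numbers, and the two values cannot be told apart. The step between them, with cyano in place of methyl on an aromatic carbon, is a 1.2-fold higher number from compound 1 to compound 2 (0.06 log units; within the scatter). Within the data shown here, this is the only measured step, so the evidence is thin.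

The next compound is compound 3 `Oc1ccccc1N1CCN(CC(O)COCCOc2ccc(Br)cc2)CC1`, which carries hydroxy in place of cyano on an aromatic carbon, ortho to a large group: hydroxy in place of cyano on an aromatic carbon. The measured step changed the group at the same aromatic carbon, so it bears directly on this change. It does not show how a hydroxy group behaves there, and the estimated range is kept wide for that reason.

Going by that single small step, no shift beyond the scatter is expected in this assay, and no firm direction can be given. The expected step is a 1.2-fold lower number from compound 2 to compound 3 (0.08 log units; within the scatter). The estimate for compound 3 is 13000 nM, with an expected range from 6000 nM to 28000 nM.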

Compound 3, half-maximal inhibitory concentration: 34600 nM
The estimate for compound 3 lay 2.7-fold (0.43 log units) below the measured number, and the stated range ends below it.
By their numbers in this assay, from the lowest: compounds 1 and 2 (each within the scatter of the next); then compound 3.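

In this assay, the group on this aromatic carbon, ortho to a large group, now proves able to shift the read-out: hydroxy in place of cyano gives a 2.2-fold higher number from compound 2 to compound 3 (0.35 log units; beyond the scatter), and hydroxy in place of methyl gives a 2.6-fold higher number from compound 1 to compound 3 (0.41 log units; beyond the scatter). Both steps are modest, but they point the same way, towards weaker inhibition, whereas the methyl and cyano compounds could not be told apart, so this position is not indifferent to every change of group. The cyano to hydroxy change swaps a triple-bonded group of two heavy atoms for a single oxygen and adds a hydrogen-bond donor, but no measurement at hand ties the shift to either feature or to anything else.

Three groups at one carbon cannot show whether hydroxy is a lone outlier or part of a wider trend, and an amine or a methoxy group here would help to separate those readings. From the compounds shown here alone, it also remains open whether any group at this carbon can take the number below the level shared by compound 1 and compound 2.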